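The source may report more compounds than this note shows. Statements on the series, on what has been measured and on what is new or still open speak of the compounds shown alone.

Values in a functional assay on HFF cells (Homo sapiens) for cytotoxicity; a lower number here means a stronger inhibitor, a higher number a weaker inhibitor:

- compound 1 `COC[C@H]1O[C@@H](n2c(Cl)nc3cc(Cl)c(Cl)cc32)[C@H](OC(C)=O)[C@@H]1OC(C)=O`: 26000 nM
- compound 2 `CCOC[C@H]1O[C@@H](n2c(Cl)nc3cc(Cl)c(Cl)cc32)[C@H](OC(C)=O)[C@@H]1OC(C)=O`: 33000 nM
- compound 3 `COC[C@H]1OC(n2c(Cl)nc3cc(Cl)c(Cl)cc32)[C@H](O)[C@@H]1O`: 32000 nM

Compound 3 lies within the scatter of both compound 1 and compound 2, so the three values cannot be told apart. Compound 4 `CCOC[C@H]1OC(n2c(Cl)nc3cc(Cl)c(Cl)cc32)[C@H](O)[C@@H]1O` has not yet been measured. It differs from compound 3 by methyl in place of hydrogen on a saturated chain carbon bound to an oxygen on a saturated carbon, which turns methoxymethyl to ethoxymethyl.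

Among the compounds with values here, only one measured step bears on this change: a 1.3-fold higher number from compound 1 to compound 2 (0.10 log units; within the scatter). That pair differs from compound 3 and compound 4 elsewhere in the structure, so it is a guide and not a direct precedent. With this single step as the evidence, no change beyond the scatter is expected in this assay, and the expected step is a 1.2-fold higher number from compound 3 to compound 4 (0.07 log units; within the scatter). The estimated value for compound 4 is 38000 nM, with an expected range from 20000 nM to 70000 nM.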

Compound 4, half-maximal inhibitory concentration: 26000 nM
For compound 4 the middle estimate is 1.5-fold (0.16 log units) above the measured one, within the range that was stated.
By their numbers in this assay, from the lowest: compounds 1, 4, 3 and 2 (each within the scatter of the next).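

In this assay, the change from methoxymethyl to ethoxymethyl can now be read on a second core, and it gives a 1.2-fold lower number from compound 3 to compound 4 (0.09 log units; within the scatter). The earlier compounds shown here offered this change only once, so a single small step could not show whether the lack of an effect held beyond the core of compound 1. Compound 4 shows that it does for these two cores, where the change leaves the number within the scatter each time, and the two steps also agree with each other: the same change on two cores in this assay, a 1.3-fold higher number (0.10 log units; within the scatter) from compound 1 to compound 2 and a 1.2-fold lower number (0.09 log units; within the scatter) from compound 3 to compound 4, 1.6-fold (0.19 log units) apart, within the scatter of two such steps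

The compounds shown leave open whether a longer chain, such as propoxymethyl, or an amine in place of the ether oxygen would move the number beyond the scatter of these four compounds. They also cannot show whether this change would stay as small on any other core.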